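Chloro for methyl on the amide chain of compound 2

The source may report more compounds than this note shows. Statements on the series, on what has been measured and on what is new or still open speak of the compounds shown alone.

Measured compounds:
compound 1, `CCC(=O)Nc1ccc(-c2nc3cc(C(F)(F)F)ccc3n2C2CCCCC2)cc1`, 18000 nM
compound 2, `CCC(=O)Nc1ccc(-c2nc3cc(C(F)(F)F)ccc3[nH]2)cc1`, > 100000 nM

In an ADME assay on MDBK cells (Bos taurus) for cytotoxicity, read by MTT assay, with a stated time of 96 h (a higher number here means that more compound is tolerated, a lower number that less compound is tolerated), compound 1 gives 18000 nM. Compound 2 reaches only the limit of the assay, > 100000 nM, and no number. The step of an at least 5.5-fold higher number from compound 1 to compound 2 (0.74 log units; beyond the scatter) is thus known only as a lower bound, since (the limit of > 100000 nM in this assay, at which 1 of the 2 values shown sits). Compound 2 therefore stands at the top of the shown numbers, above compound 1 by at least the stated margin.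

Compound 3, `O=C(CCl)Nc1ccc(-c2nc3cc(C(F)(F)F)ccc3[nH]2)cc1`, differs from compound 2 by chloro in place of methyl on a saturated chain carbon bound to a carbonyl carbon. Within the data shown here, the single measured step concerns the aromatic nitrogen and does not touch the propanoylamino group, so it says nothing about this change. Among the measured compounds shown here, no measured step bears on a chloro in place of methyl, and no direction can be drawn from the two values shown.

With compound 2 already at the limit, compound 3 is expected to remain close to it, the estimated step being an at least 1.2-fold lower number from compound 2 to compound 3 (0.09 log units; that floor lies within the scatter). For compound 3 the estimate in this assay is 80000 nM, between 20000 nM and 200000 nM.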

Compound 3, half-maximal cytotoxic concentration: 17000 nM
Estimate against measurement, compound 3: 4.7-fold (0.67 log units) above, and the stated range ends above it.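

In this assay, the amide chain proves to matter: chloro in place of methyl on a saturated chain carbon bound to a carbonyl carbon gives an at least 5.8-fold lower number from compound 2 to compound 3 (0.76 log units; beyond the scatter). Among these compounds, the only earlier step concerned the aromatic nitrogen, so this is the first measured sign that the propanoylamino group also bears on how much compound the cells tolerate, even though the change exchanges only one heavy atom for one heavy atom and leaves the counted hydrogen-bond donors and acceptors unchanged. Compound 2 sits at a limit of the assay rather than at a number, so the step is known only as a lower bound: the limit of > 100000 nM in this assay, at which 1 of the 3 values shown sits.

As far as these compounds go, it remains open whether the lower number is specific to chloro or would also appear with fluoro, a hydroxyl group or an amine on this chain carbon, or with a longer chain in place of the chloromethyl. From the compounds shown here alone, it is also open whether the same exchange would give a step of similar size with cyclohexyl on the aromatic nitrogen, and the values shown give no reason for the change.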